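N-Methylation of the pyrazole ring in compound 2

The source may report more compounds than this note shows. Statements on the series, on what has been measured and on what is new or still open speak of the compounds shown alone.

Measured so far in an in vitro functional assay on cells (Fibroblast) for agonist activity at Alpha-1D adrenergic receptor (Homo sapiens); a higher number here means that more compound is needed for the effect, a lower number that less compound is needed:
Compound 1, `c1ccc(-c2nc[nH]n2)c(NCC2=NCCN2)c1`: compound 1 gives 3.98 nM.
Compound 2, `c1ccc(-c2cn[nH]c2)c(NCC2=NCCN2)c1`: compound 2 gives 20 nM.

Compound 2 stands at the highest of the two numbers in this assay. Among the compounds with values here, the single measured step, a 5.0-fold higher number from compound 1 to compound 2 (0.70 log units; beyond the scatter), separates it from compound 1 and concerns the exchange of one five-membered ring for another on the aromatic carbon.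

Compound 3, `Cn1cc(-c2ccccc2NCC2=NCCN2)cn1`, differs from compound 2 by methyl in place of hydrogen on an aromatic nitrogen. Within the data shown here, no measured step covers a change of this kind: the one step known swaps whole rings rather than placing a methyl group on a ring nitrogen, so it offers no direct guide to the direction or size of the effect here. With nothing more to go on, the step from compound 2 to compound 3 in this assay is expected to be small, quite possibly within the scatter, and a wide range in either direction has to be allowed. Compound 3 is therefore estimated at 30 nM (range 8 nM to 110 nM), which corresponds to an expected step of a 1.5-fold higher number from compound 2 to compound 3 (0.18 log units; within the scatter).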

Compound 3, half-maximal effective concentration: < 100000 nM
Compound 3: only a limit was reported; the forecaster's own chance of this, stated with the estimate: 5%; the middle value does not contradict the limit.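

In this assay compound 3 gives < 100000 nM, which is a limit and not a number. The steps from compound 1 and from compound 2 to compound 3 cannot be read. The compounds shown leave open how large a change in this assay goes with methyl in place of hydrogen on an aromatic nitrogen, and in which direction.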